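Methoxy on the series: expected step to compound 4

The compounds below may be only part of what the source reports. "The series", "measured", "known", "first", "only" and "open" are said of these compounds alone.

Measured in a functional assay on MCF7 cells (Homo sapiens) for antiproliferative activity, read by MTT assay, with a stated time of 48 h; a higher number here means a weaker inhibitor, a lower number a stronger inhibitor:
- compound 1 `N=C(N)N/N=C(/C=C/c1ccccc1)c1ccccc1`: 17000 nM
- compound 2 `N=C(N)N/N=C(/C=C/c1ccc(-c2ccccc2)cc1)c1ccccc1`: 800 nM
- compound 3 `N=C(N)N/N=C(/C=C/c1cccc([N+](=O)[O-])c1)c1ccccc1`: 6500 nM

Compound 1 carries the highest number of the three, so both measured substitutions lead to lower numbers. Compound 4 `COc1ccccc1/C=C/C(=N/NC(=N)N)c1ccccc1` has not yet been measured. It differs from compound 1 as follows: methoxy in place of hydrogen on an aromatic carbon. That is, methoxy in place of hydrogen on an aromatic carbon, ortho to a large group.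

Within the data shown here, two measured steps bear on this change. The step of a 2.6-fold lower number from compound 1 to compound 3 (0.42 log units; beyond the scatter) is modest, while the step of a 21-fold lower number from compound 1 to compound 2 (1.33 log units; beyond the scatter) is large. Among the measured compounds shown here, no methoxy compound has been measured, so the guidance is indirect. Methoxy adds no ring, and neither does nitro, so the modest step is taken as the closer guide. A small to modest move toward a lower number is expected in this assay, and no change beyond the scatter remains possible.

Compound 4 is estimated at 8000 nM, with an expected range of 2500 nM to 20000 nM. The estimate means a 2.1-fold lower number from compound 1 to compound 4 (0.33 log units; beyond the scatter).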

Compound 4, half-maximal inhibitory concentration: 7200 nM
Estimate against measurement, compound 4: 1.1-fold (0.05 log units) above, and the stated range covers the measured number.
By their numbers in this assay, from the lowest: compound 2; then compounds 3 and 4 (each within the scatter of the next); then compound 1.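

In this assay, methoxy on an aromatic carbon, ortho to a large group, gives a 2.4-fold lower number from compound 1 to compound 4 (0.37 log units; beyond the scatter), so this place on the core of compound 1 accepts a substituent without a loss of activity. The step is modest, like a 2.6-fold lower number from compound 1 to compound 3 (0.42 log units; beyond the scatter), and much smaller than a 21-fold lower number from compound 1 to compound 2 (1.33 log units; beyond the scatter); all three substitutions shown lower the number, and the two that add no ring give the smaller steps. The data in hand offer no explanation for the size of the methoxy step.

Whether the step belongs to methoxy itself or to its place remains open, as no single group is shown at more than one place on this ring. An amine, a hydroxyl or a longer chain such as ethoxy at this same place would test how far the modest gain extends.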